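The compounds below may be only part of what the source reports. "The series", "measured", "known", "first", "only" and "open" are said of these compounds alone.

Compound 1 `CCNC(=O)[C@H]1O[C@@H](n2cnc3c(NNC(=O)c4ccccc4)ncnc32)[C@H](O)[C@@H]1O` gives in an assay on CHO cells for displacement of a labelled ligand from adenosine receptor A3 (Homo sapiens) (on this read-out lower numbers stand for stronger inhibition and higher numbers for weaker inhibition), only a limit, > 5000 nM.
Compound 2 `CCNC(=O)[C@H]1O[C@@H](n2cnc3c(NNC(=O)c4ccccc4)nc(Cl)nc32)[C@H](O)[C@@H]1O` gives in this assay likewise only a limit, > 5000 nM.

Both measured values sit at the same limit, (the limit of > 5000 nM in this assay, at which 2 of the 2 values shown sit), so compound 2 stands at the edge of what this assay reports, without a number of its own. Going by the values given here, the only measured step, a step that the two limits leave unreadable from compound 1 to compound 2, is a change from hydrogen to chloro on an aromatic carbon whose size cannot be read, since it joins two limits. Compound 3 `CCNC(=O)[C@H]1O[C@@H](n2cnc3c(NNC(=O)c4ccco4)nc(Cl)nc32)[C@H](O)[C@@H]1O` differs from compound 2 by furan-2-yl in place of phenyl on a carbonyl carbon. No measured step covers this kind of change, and the one step shown has no readable size, so there is nothing to suggest a large move in either direction. Compound 3 is therefore expected to remain near the limit, with a step that the limit leaves unreadable from compound 2 to compound 3 expected to be small. The estimate for compound 3 is 6000 nM, between 1500 nM and 25000 nM.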

Compound 3, inhibition constant: > 5000 nM
Compound 3 ended at the assay's limit (the forecaster's own chance of this, stated with the estimate: 75%); the middle value does not contradict the limit.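

No new step can be read from compound 2 to compound 3, as both results in this assay are limits rather than numbers: the limit of > 5000 nM in this assay, at which 3 of the 3 values shown sit. The compounds shown leave open how strong the inhibition by each really is, and whether swapping hydrogen for chloro or phenyl for furan-2-yl changes it.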